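Moving a Methoxy Group on the Cinnamate Ring

A few compounds are considered here, and "the series" means these few. Any claim that something is new, unique, unknown or untested is made for them only; others in the source may bear on it.

Measured so far:
compound 1 `COc1ccccc1/C=C/C(=O)OC/C=C/c1cc(OC)c(OC)cc1OC` gives 50%
compound 2 `COc1cc(OC)c(OC)cc1/C=C/COC(=O)/C=C/c1ccc(Br)cc1` gives 25%

Both compounds were tested in a functional assay on the whole organism (strain Kunming) with Mus musculus as the target, with a stated time of 0.5 h, at a dose of 300 mg/kg by the intraperitoneal route; on this read-out higher numbers stand for a weaker effect at the one dose given and lower numbers for a stronger effect. Compound 1 holds the highest number of the two; its nearest neighbour is compound 2, and the step of a number 25 percentage points lower from compound 1 to compound 2 (beyond the scatter) lies beyond the scatter, so compound 2 shows the stronger effect at the dose given.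

The compound still to be measured is compound 3 `COc1ccc(/C=C/C(=O)OC/C=C/c2cc(OC)c(OC)cc2OC)cc1`. It differs from compound 1 by 4-methoxyphenyl in place of 2-methoxyphenyl on a double-bonded chain carbon bound to a double-bonded chain carbon. The same atoms are present in both; only the position of the methoxy group on the ring at that end of the chain changes.

For the measured compounds named here, only one measured step touches this part of the molecule, a number 25 percentage points lower from compound 1 to compound 2 (beyond the scatter), and that step swaps the whole group, not merely its position. It shows the read-out can shift when this ring is altered, but it gives no direct guide to a methoxy group moved from one position to another. A modest change toward a lower number, or none beyond the scatter, is expected for compound 3, as the step of a number 10 percentage points lower from compound 1 to compound 3 (within the scatter) is estimated. In this assay compound 3 is expected to give about 40%, within a range of 20% to 65%.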

Compound 3, a percentage reported as activity, at one dose (the size of the read-out at that dose, not a potency): 0%
Estimate against measurement, compound 3: 40 percentage points above, and the stated range ends above it.
By their numbers in this assay, from the lowest: compound 3; then compound 2; then compound 1.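

In this assay, for the compounds shown here, a number 50 percentage points lower from compound 1 to compound 3 (beyond the scatter) shows for the first time that where the methoxy group sits on this ring matters on its own, since 2-methoxyphenyl and 4-methoxyphenyl have the same atoms and the same counts of donors and acceptors. The a number 25 percentage points lower from compound 2 to compound 3 (beyond the scatter) adds that the group itself also counts: with methoxy in place of bromo on an aromatic carbon, the number falls again, and compound 3 now shows the strongest effect of the three at the one dose given. Nothing measured here bears on why either change moves the read-out, so these steps describe an outcome and not a cause.

The compounds shown leave open whether a 3-methoxyphenyl group would follow the 2-methoxyphenyl or the 4-methoxyphenyl result, and whether a hydroxy group or an amine could stand in for the methoxy group of 4-methoxyphenyl. They also leave open whether the result holds at other doses, since a single-dose reading is a size of effect at that dose and not a potency.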